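A few compounds are considered here, and "the series" means these few. Any claim that something is new, unique, unknown or untested is made for them only; others in the source may bear on it.

Three compounds share one core, and their numbers in an ADME assay on PC-3 cells (Homo sapiens) for cytotoxicity, read by sulforhodamine B assay, with a stated time of 48 h, tested at 10 uM (a lower number here means less inhibition, a higher number more inhibition at the concentration tested (going by the name of the read-out)), sit close together. Compound 1 `COc1nc2ccc(Br)cc2cc1C(c1ccccc1)n1cc(-c2ccccc2F)nn1` gives 13.4%. Compound 2 `CCCCc1cn(C(c2ccccc2)c2cc3cc(Br)ccc3nc2OC)nn1` gives 5.54%, and compound 3 `CCCCCCCc1cn(C(c2ccccc2)c2cc3cc(Br)ccc3nc2OC)nn1` gives 4.42%. The steps of a number 7.9 percentage points lower from compound 1 to compound 2 (within the scatter) and a number 9 percentage points lower from compound 1 to compound 3 (within the scatter) both fall within the scatter, as does a number 1.1 percentage points lower from compound 2 to compound 3 (within the scatter), so none of the three can be called apart from the others on this evidence.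

Compound 4 `COc1nc2ccc(Br)cc2cc1C(c1ccccc1)n1cc(-c2cccc(F)c2)nn1` is compound 3 with one change: 3-fluorophenyl in place of heptyl on an aromatic carbon. The step that bears most on this is a number 9 percentage points lower from compound 1 to compound 3 (within the scatter), where a fluorophenyl ring gave way to the heptyl chain; the present change runs the other way, with a fluorine on a different ring position. Since that step and also a number 7.9 percentage points lower from compound 1 to compound 2 (within the scatter) stayed within the scatter, the return to an aromatic group is expected to move the number back toward compound 1 without leaving the scatter.

For compound 4 the expected value is 12%, with a range of 2% to 25%, and the expected step is a number 7.6 percentage points higher from compound 3 to compound 4 (within the scatter).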

Compound 4, a percentage reported as inhibition, at one concentration (the size of the read-out at that concentration, not a potency): 14.6%
The estimate for compound 4 lay 2.6 percentage points below the measured number, within the range that was stated.
By their numbers in this assay, from the lowest: compounds 3, 2, 1 and 4 (each within the scatter of the next, the first and the last beyond it).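

In this assay, going by these compounds alone, on this carbon of the five-membered ring, 3-fluorophenyl in place of heptyl gives a number 10.2 percentage points higher from compound 3 to compound 4 (beyond the scatter), the only step in this set beyond the scatter, and a modest one. The same ring in place of butyl gives a number 9.1 percentage points higher from compound 2 to compound 4 (within the scatter) and 3-fluorophenyl in place of 2-fluorophenyl gives a number 1.2 percentage points higher from compound 1 to compound 4 (within the scatter), so neither swap separates its pair, and the ring-for-chain difference rests on the heptyl pair alone. Nothing available explains why the heptyl pair separates.

From the compounds shown here alone, it remains open whether an unsubstituted phenyl, a 4-fluorophenyl or a chain ending in an amine or a carboxylic acid would read like the fluorophenyl compounds or like the chains. All these numbers are also small inhibition readings at a single concentration, so they give no potency.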